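The compounds below may be only part of what the source reports. "The series", "measured", "known", "first", "only" and "open" are said of these compounds alone.

In a functional assay on the whole organism (strain Sprague-Dawley) for inhibition, with Rattus norvegicus as the target, with a stated time of 10 min (a higher number here means that more compound is needed for the effect, a lower number that less compound is needed), compound 1 (`CCOC(=O)c1cnc(-c2ccccc2OCC)[nH]c1=O`) gives 2 mg/kg and compound 2 (`CCOC(=O)c1cnc(-c2ccccc2OC(C)C)[nH]c1=O`) gives 2 mg/kg at the digits shown, which leaves compound 2 level with compound 1. Compound 3 (`CCOC(=O)c1cnc(-c2ccccc2SC)[nH]c1=O`) carries methylsulfanyl in place of isopropoxy on an aromatic carbon. Within the data shown here, the only measured step of no change at the digits printed from compound 1 to compound 2 (within the scatter) stays within the scatter, but it alters the chain on oxygen and never replaces the oxygen-linked group. It offers weak guidance, so no change beyond the scatter is expected in this assay and no direction is favoured. The estimated change is no change at the digits printed from compound 2 to compound 3 (within the scatter) with wide uncertainty. The expected dose for compound 3 is 2 mg/kg (range 0.6 mg/kg to 7 mg/kg).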

Compound 3, dose for 50% inhibition: > 25 mg/kg
Compound 3 was reported as a limit (the forecaster's own chance of this, stated with the estimate: 10%); at least 12-fold (1.09 log units) between middle value and limit.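

Ethoxy and isopropoxy stand level on this aromatic carbon, but methylsulfanyl is not tolerated there in this assay: in place of isopropoxy it gives an at least 12-fold higher number from compound 2 to compound 3 (1.09 log units; beyond the scatter), and in place of ethoxy it gives an at least 12-fold higher number from compound 1 to compound 3 (1.09 log units; beyond the scatter). Compound 3 is reported only as a limit, so the full size of both steps stays open: the limit of > 25 mg/kg in this assay, at which 1 of the 3 values shown sits.

Methoxy or ethylsulfanyl on this carbon would separate the exchange of oxygen for sulfur from the shorter chain. The compounds shown cannot tell these two apart.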